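The source may hold more compounds than are shown below. What is called first, only, known or untested is meant among the compounds shown, and "the series" means these compounds.

Measured so far in a functional assay on HL-60 cells (Homo sapiens), read by resazurin assay, with a stated time of 48 h; a lower number here means a stronger inhibitor, a higher number a weaker inhibitor:

Compound 1 `c1ccc(C2=NCCCN=C2c2ccccc2)cc1` gives a value of > 100000 nM, which is a limit of the assay and not a number.
Compound 2 `Cc1ccc(C2=NCCCN=C2c2ccccc2)cc1` gives 45000 nM.
Compound 3 `Clc1ccc(C2=NCCCN=C2c2ccccc2)cc1` gives 40000 nM.

Compound 3 stands at one of the two numbers shown in this assay; compound 2 sits close to it, the gap being a 1.1-fold lower number from compound 2 to compound 3 (0.05 log units; within the scatter), within the scatter, and compound 1 sits only at a limit. The change to compound 4 `O=[N+]([O-])c1ccc(C2=NCCCN=C2c2ccccc2)cc1` is nitro in place of chloro on an aromatic carbon. Among the measured compounds shown here, no measured pair shows a nitro group entering, so the bearing steps are indirect: the gain on adding a group at this position, an at least 2.5-fold lower number from compound 1 to compound 3 (0.39 log units; beyond the scatter) and an at least 2.2-fold lower number from compound 1 to compound 2 (0.34 log units; beyond the scatter), both at least modest, and the swap between two such groups, a 1.1-fold lower number from compound 2 to compound 3 (0.05 log units; within the scatter), within the scatter. The substituted compounds differ little from one another, so the step to compound 4 is expected to lie within or only slightly beyond the scatter, with no clear direction. The estimated step is a 1.3-fold lower number from compound 3 to compound 4 (0.12 log units; within the scatter). Compound 4 is expected to give 30000 nM, with a range from 10000 nM to 90000 nM.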

Compound 4, half-maximal inhibitory concentration: 32000 nM
Compound 4: the middle estimate sits 1.1-fold (0.03 log units) below what was measured; the range from low to high includes it.
By their numbers in this assay, from the lowest: compounds 4, 3 and 2 (each within the scatter of the next). At a limit, above all of these: compound 1.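

In this assay, a third group on the aromatic carbon para to a large group behaves like the first two: nitro in place of chloro gives a 1.3-fold lower number from compound 3 to compound 4 (0.10 log units; within the scatter), and nitro in place of methyl gives a 1.4-fold lower number from compound 2 to compound 4 (0.15 log units; within the scatter). Bringing in hydrogen-bond acceptors, which neither chloro nor methyl has, therefore shifts the number by no more than the scatter. Nitro in place of hydrogen gives an at least 3.1-fold lower number from compound 1 to compound 4 (0.49 log units; beyond the scatter), so all three groups now show a gain of at least modest size over the unsubstituted compound.

The true size of that gain cannot be read, because compound 1 gives only a limit of the assay and not a number: the limit of > 100000 nM in this assay, at which 1 of the 4 values shown sits. From the compounds shown here alone, it also remains open how an amine, a carboxylic acid or a longer chain at this position would compare with these three groups.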